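The source may report more compounds than this note shows. Statements on the series, on what has been measured and on what is new or still open speak of the compounds shown alone.

Three compounds that share one core and differ only in the group on an aromatic nitrogen have been measured in an ADME assay on liver for metabolic stability, with Liver microsome (Homo sapiens) as the target, using microsomes, with a stated time of 10 min, tested at 0.5 uM; a lower number here means that less of the compound is left, a higher number that more of the compound is left. Compound 1 `Cc1ccncc1-c1cccc2c1cnn2-c1nccs1`, with a thiazolyl group, gives 69%. Compound 2 `Cc1ccncc1-c1cccc2c1cnn2-c1ccccc1`, with phenyl, gives 78%. Compound 3 `Cc1ccncc1-c1cccc2c1cnn2-c1ccc(F)cc1`, with 4-fluorophenyl, gives 100%, the highest of the three numbers.

The next compound is compound 4 `Cc1ccncc1-c1cccc2c1cnn2-c1ccccn1`, which has not yet been measured. It has pyridin-2-yl in place of 4-fluorophenyl on an aromatic nitrogen.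

Within the data shown here, three measured steps bear on this change. Adding the fluoro group to phenyl gave a number 22 percentage points higher from compound 2 to compound 3 (beyond the scatter), a modest step. Replacing the thiazolyl group with 4-fluorophenyl gave a number 31 percentage points higher from compound 1 to compound 3 (beyond the scatter), a large one. Replacing it with plain phenyl gave only a number 9 percentage points higher from compound 1 to compound 2 (within the scatter), which does not separate the two compounds.

Compound 4 has no fluorine, so it may fall in the same region as compound 1 at 69% and compound 2 at 78%. Among the measured compounds shown here, with only three measured compounds, this remains a tentative expectation. A clear fall in this assay is therefore expected, and the estimated change is a number 25 percentage points lower from compound 3 to compound 4 (beyond the scatter). The estimated value for compound 4 is 75%, within an expected range of 58% to 92%.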

Compound 4, percent of the compound remaining: 95%
Estimate against measurement, compound 4: 20 percentage points below; the whole stated range lies below it.
By their numbers in this assay, from the lowest: compounds 1 and 2 (each within the scatter of the next); then compounds 4 and 3 (each within the scatter of the next).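

In this assay, the fluoro group turns out not to be needed for a high number at this position: putting pyridin-2-yl in place of 4-fluorophenyl gives a number 5 percentage points lower from compound 3 to compound 4 (within the scatter) and so does not separate the two compounds. The same group clearly departs from the two lower compounds, with a number 17 percentage points higher from compound 2 to compound 4 (beyond the scatter) and a number 26 percentage points higher from compound 1 to compound 4 (beyond the scatter), which shows that swapping one six-membered aromatic ring for another can matter here even without fluorine; compound 1 goes against any simple rule that a ring nitrogen alone is enough, since its thiazolyl group also holds one and it stays with compound 2 in the lower pair. Why these groups on the aromatic nitrogen differ in this way cannot be said from what is available.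

The compounds shown leave open whether the place of the ring nitrogen matters, which pyridin-3-yl or pyridin-4-yl could test against pyridin-2-yl. They also leave open how a group without an aromatic ring, such as cyclohexyl or a short alkyl chain, would behave on this same nitrogen.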